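Amino in Place of Hydrogen on a Nucleoside Ester Core

The compounds below may be only part of what the source reports. "The series", "measured", "known", "first", "only" and "open" are said of these compounds alone.

Compound 1 `Nc1ncnc2c1ncn2[C@@H]1O[C@H](COC(=O)c2cc[nH]c2)[C@@H](O)[C@H]1O`: 98%
Compound 2 `Nc1ncnc2c1ncn2[C@@H]1O[C@H](COC(=O)c2ccc[nH]2)[C@@H](O)[C@H]1O`: 95%
Compound 3 `O=C(OC[C@H]1O[C@@H](n2cnc3c(=O)[nH]cnc32)[C@H](O)[C@@H]1O)c1ccc[nH]1`: 97%

In an assay for inhibition of Maternal embryonic leucine zipper kinase (Homo sapiens), read by Z'-LYTE, with a stated time of 1 h, tested at 10 uM (a higher number here means more inhibition at the concentration tested (going by the name of the read-out), a lower number less inhibition), compound 3 gives 97%, a number that sits with those of compound 1 and compound 2 within the usual scatter. Compound 4 `Nc1nc2c(ncn2[C@@H]2O[C@H](COC(=O)c3ccc[nH]3)[C@@H](O)[C@H]2O)c(=O)[nH]1` differs from compound 3 by amino in place of hydrogen on an aromatic carbon. Among the compounds with values here, no measured step involves this change; the only measured step, a number 3 percentage points lower from compound 1 to compound 2 (within the scatter), alters the ester ring instead and is itself within the scatter. The three measured compounds, with different cores and ester rings, all give high inhibition, so compound 4 is expected to follow them, with a number 2 percentage points lower from compound 3 to compound 4 (within the scatter). Compound 4 is therefore estimated at 95%, in a range from 85% to 100%.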

Compound 4, a percentage reported as inhibition, at one concentration (the size of the read-out at that concentration, not a potency): 96%
For compound 4 the middle estimate is 1 percentage points below the measured one, within the range that was stated.
By their numbers in this assay, from the lowest: compounds 2, 4, 3 and 1 (each within the scatter of the next).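

With amino in place of hydrogen on this aromatic carbon, between two ring nitrogen atoms, the result in this assay is a number 1 percentage points lower from compound 3 to compound 4 (within the scatter). Within the data shown here, this is the first measured change at this position, and it shows that the position can carry an amino group while inhibition stays high. Nothing available explains this result.

As far as these compounds go, all of these readings are high and come from one concentration, so any difference in potency between the two compounds remains open. From the compounds shown here alone, how a methylamino group or a carboxylic acid at this carbon would read also remains open.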